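From Methoxy to Hydroxy: a Single-Atom Change Weighed

The source may report more compounds than this note shows. Statements on the series, on what has been measured and on what is new or still open speak of the compounds shown alone.

Of the compounds shown here, three have so far been tested in a functional assay on the whole organism (strain Swiss albino) with Mus musculus as the target, with a stated time of 0.5 h; a lower number here means that less compound is needed, a higher number that more compound is needed for the effect. Compound 1 `CC12CCC(C/C1=N/Cc1cccnc1)C2(C)C` gives 30 mg/kg. Compound 2 `C/C(=N\Cc1cccnc1)c1ccccc1` gives 30 mg/kg in this assay. Compound 3 `COc1ccc(/C=N/Cc2cccnc2)cc1OC` gives 30 mg/kg in this assay. Compound 3 therefore stands level with compound 1 and with compound 2 at the digits shown; its gap to either lies within the usual scatter of repeated measurements, so no order among the three can be claimed.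

Compound 4 `COc1cc(/C=N/Cc2cccnc2)ccc1O` has not yet been measured. It differs from compound 3 in one place only: hydrogen in place of methyl on an oxygen on an aromatic ring. Seen one bond further out, a methoxy becomes a hydroxy.

Within the data shown here, no pair of measured compounds here shows what such a change does, so the expectation rests on the wider picture: three compounds built on quite different cores all return the same number, and the change to compound 4 removes only one heavy atom. Compound 4 is therefore expected to give 30 mg/kg in this assay, with a range of 15 mg/kg to 60 mg/kg. The step of no change at the digits printed from compound 3 to compound 4 (within the scatter) that this estimate means is expected to be none beyond the scatter.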

Compound 4, minimum effective dose: 30 mg/kg
For compound 4 middle estimate and measured number coincide at the digits printed; low and high end bracket the measured number.
By their numbers in this assay, from the lowest: compounds 1, 2, 3 and 4 (each within the scatter of the next).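

Replacing the methyl on an oxygen on an aromatic ring with hydrogen, so that a methoxy becomes a hydroxy, gives no change at the digits printed from compound 3 to compound 4 (within the scatter) in this assay. Among these compounds, this is the first pair here that differs in one place only, so it gives a direct reading of a single change instead of a comparison across different cores: on this compound, at this oxygen, the methyl can be lost without a shift in minimum effective dose that this measurement can distinguish. No measurement bears on what lies behind this result, so it stands as an observation only.

Still open, on these data alone, is whether this oxygen tolerates other changes, such as an ethyl or a longer chain in place of the methyl, or an amine or a carboxylic acid in place of the hydroxy. Also open, as far as these compounds go, is whether the same step from methoxy to hydroxy would read the same at the other methoxy of compound 3, or with both methoxy groups replaced by hydroxy groups.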